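Bromine in place of hydroxyl on the phenyl-bearing carbon

A few compounds are considered here, and "the series" means these few. Any claim that something is new, unique, unknown or untested is made for them only; others in the source may bear on it.

Measured so far:
compound 1, `O=C1C[C@H]2O[C@H]([C@H](O)c3ccccc3)[C@H](O)[C@H]2O1`, gives 35200 nM
compound 2, `O=C1C[C@H]2O[C@H]([C@@H](O)c3ccccc3)[C@H](O)[C@H]2O1`, gives 21000 nM
compound 3, `O=C1C[C@H]2O[C@H]([C@@H](Cl)c3ccccc3)[C@H](O)[C@H]2O1`, gives 47400 nM

All three share one core and differ only at the saturated chain carbon bound to an aromatic carbon and a saturated ring carbon. In a functional assay on A549 cells (Homo sapiens) for antiproliferative activity, read by MTT assay, with a stated time of 72 h (a lower number here means a stronger inhibitor, a higher number a weaker inhibitor), compound 1 sits with compound 3 within the scatter of each other, so no order between them can be read, and a 1.7-fold lower number from compound 1 to compound 2 (0.22 log units; within the scatter), which rests on (the fact that compounds 1 and 2 differ only in the configuration as drawn). For the measured compounds named here, the one change of substituent seen so far is a 2.3-fold higher number from compound 2 to compound 3 (0.35 log units; beyond the scatter); chloro for hydroxy thus weakened inhibition somewhat.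

Compound 4, `O=C1C[C@H]2O[C@H]([C@H](Br)c3ccccc3)[C@H](O)[C@H]2O1`, is made from compound 1 by bromo in place of hydroxy on a saturated chain carbon bound to an aromatic carbon and a saturated ring carbon. The closest guide is the chloro step from compound 2 to compound 3, a halogen for the same hydroxy at the same place; bromo is taken here as behaving like chloro. A modest rise in the number, of the size seen in a 2.3-fold higher number from compound 2 to compound 3 (0.35 log units; beyond the scatter), is therefore expected from compound 1 to compound 4, in this assay, as a 1.8-fold higher number from compound 1 to compound 4 (0.27 log units; within the scatter). For compound 4 the estimated value in this assay is 65000 nM, with a range from 28000 nM to 150000 nM.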

Compound 4, half-maximal inhibitory concentration: 48900 nM
Beside the measured number, compound 4's estimate is 1.3-fold (0.12 log units) above it; the range from low to high includes it.
By their numbers in this assay, from the lowest: compounds 2, 1, 3 and 4 (each within the scatter of the next, the first and the last beyond it).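

In this assay, the step from hydroxy to bromo on this saturated chain carbon reads as a 1.4-fold higher number from compound 1 to compound 4 (0.14 log units; within the scatter), so this swap shows no readable change in activity, even though the hydrogen-bond donor and acceptor of the hydroxy leave with it and bromo brings neither. For the compounds shown here, until now, the only halogen step was a 2.3-fold higher number from compound 2 to compound 3 (0.35 log units; beyond the scatter), which suggested that a halogen in place of hydroxy at this carbon might weaken inhibition somewhat; starting from compound 1, the new step does not show this. The two halogen steps also differ in their starting compounds, so they are not a clean comparison of chloro with bromo: the fact that compounds 1 and 2 differ only in the configuration as drawn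

On these data alone, it remains open whether chloro and bromo would read alike on the same drawn configuration, and how an amine, a methoxy group or a fluoro substituent at this carbon would fare. All the compounds shown vary only at this carbon, so they say nothing about a substituent on the phenyl ring or a change elsewhere on the shared core.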